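Swapping a thioamide for a dithiolethione on an aryl ester

The compounds below may be only part of what the source reports. "The series", "measured", "known", "first", "only" and "open" are said of these compounds alone.

Measured compounds:
- compound 1, `CC(C)Cc1ccc(C(C)C(=O)Oc2ccc(-c3cc(=S)ss3)cc2)cc1`: 0.0233 h
- compound 2, `CC(C(=O)Oc1ccc(C(N)=S)cc1)c1ccc(C(=O)c2ccccc2)cc1`: 0.163 h

Of the compounds shown here, two have been measured in a physicochemical assay for pharmacokinetics, read by spectrophotometry, in phosphate buffer, with a stated time of 5 min, tested at 40 uM, in the presence of a further agent that is not named here; on this read-out higher numbers stand for a longer-lived compound and lower numbers for a shorter-lived compound. Compound 1, `CC(C)Cc1ccc(C(C)C(=O)Oc2ccc(-c3cc(=S)ss3)cc2)cc1`, gives 0.0233 h in this assay. Compound 2, `CC(C(=O)Oc1ccc(C(N)=S)cc1)c1ccc(C(=O)c2ccccc2)cc1`, gives 0.163 h in this assay. Of the two numbers, compound 2 stands higher, and the gap down to compound 1 is beyond the usual scatter; the two share no single-point difference, since both the ester side and the aryl side differ.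

Compound 3, `CC(C(=O)Oc1ccc(-c2cc(=S)ss2)cc1)c1ccc(C(=O)c2ccccc2)cc1`, has not yet been measured. It keeps the ester side of compound 2 and changes the aryl side: a group of 6 heavy atoms (3 carbon, 3 sulfur; one five-membered aromatic ring with 2 hetero atoms) in place of a group of 3 heavy atoms (1 carbon, 1 nitrogen, 1 sulfur; no ring), on an aromatic carbon. The group that enters is the same one carried by compound 1. Going by the values given here, no measured pair isolates this single change, so the expectation rests on the two values shown. The step from compound 2 to compound 3 in this assay is expected to be downward and beyond the scatter, a 4.1-fold lower number from compound 2 to compound 3 (0.61 log units; beyond the scatter), because compound 1, carrying the entering group, gives 0.0233 h. Compound 3 is therefore estimated at 0.04 h, with a range from 0.015 h to 0.12 h.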

Compound 3, half-life: 0.0567 h
Compound 3: the middle estimate sits 1.4-fold (0.15 log units) below what was measured, and the stated range covers the measured number.
By their numbers in this assay, from the lowest: compound 1; then compound 3; then compound 2.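

In this assay, putting the dithiolethione in place of the thioamide, on an aromatic carbon para to a large group, gives a 2.9-fold lower number from compound 2 to compound 3 (0.46 log units; beyond the scatter). With the ester side held fixed, this shows that the group at this position does move the half-life on its own. The ester side matters as well: benzoyl in place of isobutyl on an aromatic carbon gives a 2.4-fold higher number from compound 1 to compound 3 (0.39 log units; beyond the scatter), so a change at either of the two places shifts the number, and compound 3 ends up between the other two compounds. Nothing available explains why either step goes the way it does.

As far as these compounds go, only the thioamide and the dithiolethione appear at this position, so it remains open how a plain amide or a carboxylic acid there would compare with them. Going by these compounds alone, it also remains open whether benzoyl in place of isobutyl would produce a step of similar size and direction with the thioamide on the aryl side, as that step has been seen only with the dithiolethione in place.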